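The source may hold more compounds than are shown below. What is called first, only, known or untested is meant among the compounds shown, and "the series" means these compounds.

Of the compounds shown here, three of this study have been tested in a functional assay on Huh-7 cells (Homo sapiens) for cytotoxicity, read by MTT assay, with a stated time of 3 days; on this read-out lower numbers stand for higher toxicity in this test and higher numbers for lower toxicity in this test. Compound 1, `CC(=O)N(Cc1ncnc2c1ncn2[C@@H]1O[C@H](CO)[C@@H](O)[C@H]1O)C1CCCCC1`, reaches only the limit of the measurement and gives > 100000 nM. Compound 2, `O=c1ccccn1Cc1ncnc2c1ncn2[C@@H]1O[C@H](CO)[C@@H](O)[C@H]1O`, likewise reaches only the limit and gives > 100000 nM. Compound 3, `OC[C@H]1O[C@@H](n2cnc3c(CS)ncnc32)C[C@@H]1O`, gives a number, 41000 nM.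

So compound 2 stands at a limit rather than at a measured value, and one of the other two values shown is a limit of the same kind; this is the limit of > 100000 nM in this assay, at which 2 of the 3 values shown sit. Going by the values given here, no pair of measured compounds differs in one place only, so no measured step is available.

Compound 4, `OC[C@H]1O[C@@H](n2cnc3c(Cn4cccn4)ncnc32)[C@H](O)[C@@H]1O`, is not yet measured. It differs from compound 2 in one place: a group of 5 heavy atoms (3 carbon, 2 nitrogen; one five-membered aromatic ring with 2 hetero atoms) in place of a group of 7 heavy atoms (5 carbon, 1 nitrogen, 1 oxygen; one six-membered aromatic ring with 1 hetero atom), on a saturated chain carbon bound to an aromatic carbon. Among the compounds with values here, with no measured step to lean on, the step from compound 2 to compound 4 in this assay is expected to be none beyond the usual scatter, that is, a number no higher from compound 2 to compound 4 (the limit leaves the size open). Compound 4 is therefore estimated to give about 100000 nM, within a range from 30000 nM to 300000 nM, most likely again as a limit.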

Compound 4, half-maximal cytotoxic concentration: > 250000 nM
Compound 4 gave a limit, no number (the forecaster's own chance of this, stated with the estimate: 70%); middle value at least 2.5-fold (0.39 log units) away from the limit.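

Compound 2 and compound 4 each gave only a limit, not a number, so the step from one to the other cannot be read. The compounds shown leave open what number either would give, and whether the 1H-pyrazol-1-yl group changes the toxicity at all.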